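The source may report more compounds than this note shows. Statements on the series, on what has been measured and on what is new or still open speak of the compounds shown alone.

The series centres on a chain carrying a thioamide end, attached to a ring nitrogen of either an aromatic or a non-aromatic core. Compound 1 `N=C(S)CCn1nc(-c2ccccc2)ccc1=S` bears a phenyl group on its aromatic core and in a functional assay on the whole organism (stomach) with Rattus norvegicus as the target (on this read-out lower numbers stand for an effect already at smaller amounts and higher numbers for an effect only at larger amounts of compound), compound 1 gives 73.4 mg/kg. Compound 3 `N=C(S)CCCn1nc(-c2ccccc2)ccc1=O` carries the same phenyl group, with a carbonyl in place of the thione and a longer chain, and in this assay compound 3 gives 31.9 mg/kg. Compound 2 `CC1=NN(CCC(=N)S)C(=O)CC1` has a methyl group on a non-aromatic core, and in this assay compound 2 reaches only a limit of the assay, > 100 mg/kg. That reading places compound 2 at the limit of > 100 mg/kg in this assay, at which 1 of the 3 values shown sits; where it truly stands on the scale is not known.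

Compound 4 `N=C(S)CCN1N=C(c2cccs2)CCC1=O` has not yet been tested in this assay. It differs from compound 2 by thiophen-2-yl in place of methyl on a carbon with a double bond to nitrogen. Among the measured compounds, the two that carry an aromatic group on the core, compound 1 and compound 3, return numbers rather than a limit. On that basis compound 4 is expected to come out with a measurable value in this assay, an effect at a smaller dose than the limit seen for compound 2. The move from compound 2 to compound 4 is estimated at an at least 1.2-fold lower number from compound 2 to compound 4 (0.09 log units; that floor lies within the scatter). Compound 4 is therefore expected to give about 80 mg/kg in this assay, in an estimated range from 35 mg/kg to 200 mg/kg.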

Compound 4, dose for half-maximal effect: 77.3 mg/kg
Compound 4: the middle estimate sits 1.0-fold (0.01 log units) above what was measured; the range from low to high includes it.
By their numbers in this assay, from the lowest: compound 3; then compounds 1 and 4 (each within the scatter of the next). At a limit, above all of these: compound 2.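

On the non-aromatic core, the carbon with a double bond to nitrogen now has a second group on record: with thiophen-2-yl at that place, in this assay compound 4 gives 77.3 mg/kg, a number rather than a limit. Compound 2, with methyl at the same place, remains at a limit of the assay: the limit of > 100 mg/kg in this assay, at which 1 of the 4 values shown sits.

From the compounds shown here alone, the change therefore reads as an at least 1.2-fold lower number from compound 2 to compound 4 (0.11 log units; that floor lies within the scatter); this is only a floor, so the exchange of methyl for thiophen-2-yl has a direction that stays within the scatter at its minimum, and its true size is unknown.

Going by these compounds, it remains open how this carbon would respond to a different group, such as a furan-2-yl ring, an amine or a carboxylic acid, and so whether the number of compound 4 is particular to thiophen-2-yl or would hold for other groups at that place. On these data alone, it is equally open whether a longer chain leading to the thioamide end would shift the reading on the core that compound 4 carries.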